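The compounds below may be only part of what the source reports. "The series", "measured", "known", "first", "only" and "open" are said of these compounds alone.

Measured in a functional assay on SK-MEL-28 cells (Homo sapiens) for inhibition, read by MTT assay, with a stated time of 48 h; a higher number here means a weaker inhibitor, a lower number a stronger inhibitor:
compound 1 `C(=C/c1nc2ccccn2c1Sc1ccccc1)\c1ccccc1` gives 65400 nM
compound 2 `N#Cc1ccc(-c2nc3ccccn3c2Sc2ccccc2)cc1` gives 67500 nM
compound 3 `c1ccc(Sc2c(-c3cccs3)nc3ccccn23)cc1` gives 85300 nM

On these numbers, compound 3 cannot be separated from the other two. The next compound is compound 4 `Clc1ccc(-c2nc3ccccn3c2Sc2ccccc2)cc1`, which has 4-chlorophenyl in place of thiophen-2-yl on an aromatic carbon. The change in full is 4-chlorophenyl in place of thiophen-2-yl on an aromatic carbon on the shared core. The nearest measured exchange is a 1.3-fold higher number from compound 2 to compound 3 (0.10 log units; within the scatter) for thiophen-2-yl in place of 4-cyanophenyl on the same carbon, and it stays within the scatter. Going by the values given here, the steps of a 1.0-fold higher number from compound 1 to compound 2 (0.01 log units; within the scatter) and a 1.3-fold higher number from compound 1 to compound 3 (0.12 log units; within the scatter) also stay within the scatter, so the three groups measured on this carbon cannot be told apart, and no compound goes against that. A step beyond the scatter in this assay is therefore not expected, and no direction is expected either. The estimated size is a 1.3-fold lower number from compound 3 to compound 4 (0.10 log units; within the scatter) on this reading. Compound 4 is estimated at 68000 nM with 35000 nM to 125000 nM as the expected range.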

Compound 4, half-maximal inhibitory concentration: 73100 nM
For compound 4 the middle estimate is 1.1-fold (0.03 log units) below the measured one, within the range that was stated.
By their numbers in this assay, from the lowest: compounds 1, 2, 4 and 3 (each within the scatter of the next).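

In this assay, 4-chlorophenyl on this aromatic carbon stays within the scatter of all three earlier groups: the steps are a 1.2-fold lower number from compound 3 to compound 4 (0.07 log units; within the scatter) and a 1.1-fold higher number from compound 2 to compound 4 (0.03 log units; within the scatter) and a 1.1-fold higher number from compound 1 to compound 4 (0.05 log units; within the scatter) and none of them can be told apart from repeated measurement. The series now includes an exchange within the para-free aryl set that matters here: thiophen-2-yl, a five-membered aromatic ring with a hetero atom, gives way to a six-membered aromatic ring of carbon only with no readable step, and chloro in place of cyano on that ring also leaves no readable step. No measurement at hand explains this flat picture and the position so far tolerates every group shown without a readable change.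

Going by these compounds, whether an amine, a carboxylic acid or a simple alkyl chain on this carbon would move the number beyond the scatter remains open. On these data alone, the phenylsulfanyl group is the same in all four compounds, so the effect of replacing it is also open.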